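Methyl to cyclopropyl on the amide carbonyl of compound 3

This account rests on a few compounds, and the source may have more. Where it says the series, first, only, none or still open, it means among the compounds named here.

Of the compounds shown here, three sharing a fluorophenylsulfonamide and a primary carboxamide have been measured in a functional assay on HCT-116 cells (Homo sapiens) for antiproliferative activity, read by MTT assay, with a stated time of 72 h; on this read-out higher numbers stand for weaker inhibition and lower numbers for stronger inhibition. Compound 1 `COc1c(NS(=O)(=O)c2ccc(F)cc2)cc(-c2ccc3nc(NC4CC4)sc3n2)cc1C(N)=O` gives 35700 nM. Compound 2 `NC(=O)c1cc(-c2ccc3nc(NC(=O)C4CC4)sc3c2)cc(NS(=O)(=O)c2ccc(F)cc2)c1Cl` gives 11400 nM. Compound 3 `COc1c(NS(=O)(=O)c2ccc(F)cc2)cc(-c2ccn3nc(NC(C)=O)nc3c2)cc1C(N)=O` gives 32600 nM, the second highest of the three numbers; its nearest neighbour is compound 1, within the scatter, and the furthest is compound 2, whose lower number lies beyond the scatter. Among the compounds with values here, since compound 2 differs from compound 3 in several places at once, no single step can be drawn between them.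

Compound 4 `COc1c(NS(=O)(=O)c2ccc(F)cc2)cc(-c2ccn3nc(NC(=O)C4CC4)nc3c2)cc1C(N)=O` is not yet measured. It differs from compound 3 in one place: cyclopropyl in place of methyl on a carbonyl carbon. No measured pair among the compounds shown isolates this exchange of cyclopropyl for methyl on a carbonyl carbon, so the account can only lean on the change itself and on the numbers above.

Compound 4 is therefore expected to stand close to compound 3, with the step of a 1.3-fold lower number from compound 3 to compound 4 (0.12 log units; within the scatter) estimated to lie within the scatter, leaning if anything toward a lower number. The estimate for compound 4 in this assay is 25000 nM, with a range from 10000 nM to 60000 nM.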

Compound 4, half-maximal inhibitory concentration: > 50000 nM
Compound 4: only a limit was reported; the forecaster's own chance of this, stated with the estimate: 5%; at least 2.0-fold (0.30 log units) between middle value and limit.
By their numbers in this assay, from the lowest: compound 2; then compounds 3 and 1 (each within the scatter of the next). At a limit, above all of these: compound 4.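

Within the data shown here, the exchange of methyl for cyclopropyl on this carbonyl carbon can now be read directly in this assay, which no earlier pair allowed, and it gives an at least 1.5-fold higher number from compound 3 to compound 4 (0.18 log units; that floor lies within the scatter). Compound 4 is reported only as a limit: the limit of > 50000 nM in this assay, at which 1 of the 4 values shown sits. At this position on this core, cyclopropyl therefore shows no sign of stronger inhibition than methyl, although the floor of the step does not by itself establish a real loss.

From the compounds shown here alone, the true size of the step stays unknown, and so does how a longer chain or an amine would read on this carbonyl carbon. Going by these compounds, it also remains open whether methyl in place of cyclopropyl on the carbonyl carbon of compound 2 would give a step of similar size on that different core.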